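A few compounds are considered here, and "the series" means these few. Any claim that something is new, unique, unknown or untested is made for them only; others in the source may bear on it.

Measured so far:
Compound 1, `COC(=O)C12CC1CCN(C(=O)[C@H](CC(C)C)NC(=O)[C@H](CC(C)C)NC(=O)[C@H](CC(C)C)NC(=O)OCc1ccccc1)C2`: in an ADME assay for metabolic stability (on this read-out higher numbers stand for a longer-lived compound and lower numbers for a shorter-lived compound), compound 1 gives > 6 h, which is a limit of the assay and not a number.
Compound 2, `COC(=O)C12CC1CCN(C(=O)[C@H](CC(C)C)NC(=O)[C@H](CC(C)C)NC(=O)[C@H](CC(C)C)NC(=O)c1cccc(O)c1C)C2`: in this assay compound 2 gives > 6 h, again a limit of the assay.

Compound 2 therefore stands at the upper end of what this assay reports, and so does every other value in the set, namely (the limit of > 6 h in this assay, at which 2 of the 2 values shown sit). Among the compounds with values here, the only measured step, a step that the two limits leave unreadable from compound 1 to compound 2, runs between two limits and yields no readable size.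

Compound 3, `COC(=O)C12CC1CCN(C(=O)[C@H](CC(C)C)NC(=O)[C@H](CC(C)C)NC(=O)[C@H](CC(C)C)NC(=O)C1=CCCNC1)C2`, differs from compound 2 in one place: a group of 6 heavy atoms (5 carbon, 1 nitrogen; one six-membered non-aromatic ring with 1 hetero atom) in place of a group of 8 heavy atoms (7 carbon, 1 oxygen; one six-membered aromatic ring of carbon only), on a carbonyl carbon. No measured step covers this change; the one step shown is uninformative because both its ends sit at the limit of > 6 h in this assay, at which 2 of the 2 values shown sit. With no readable step in this assay to lean on, the expectation rests on compound 2 alone, which reads at the limit.

Compound 3 is expected to stay long-lived in this assay, estimated at 5 h with a range of 1.5 h to 12 h. The expected step is an at least 1.2-fold lower number from compound 2 to compound 3 (0.07 log units; that floor lies within the scatter), not beyond the scatter. A further limit reading is considered likely.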

Compound 3, half-life: > 6 h
Compound 3: no number, only a limit; the forecaster's own chance of this, stated with the estimate: 50%; middle value at least 1.2-fold (0.07 log units) away from the limit.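

In this assay, within the data shown here, compound 1, compound 2 and compound 3 all read at a limit and not at a number, so no step among them can be read: the limit of > 6 h in this assay, at which 3 of the 3 values shown sit. The compounds shown leave open the actual half-life of each compound in this assay, and so whether the changes on the carbonyl carbon alter it at all.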